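Swapping Sulfur for Oxygen in a Thiosemicarbazone Ring

This account rests on a few compounds, and the source may have more. Where it says the series, first, only, none or still open, it means among the compounds named here.

Measured so far in a functional assay on MCF7 cells (Homo sapiens) for cytotoxicity, read by MTT assay, with a stated time of 72 h, tested at 30 uM; a higher number here means more inhibition of growth at the concentration tested, a lower number less inhibition of growth:
- compound 1, `Cc1ccnc(/C(N)=N/NC(=S)N2CCSCC2)c1`, gives 74.2%
- compound 2, `N/C(=N\NC(=S)N1CCSCC1)c1ccccn1`, gives 72.6%
- compound 3, `Cc1ccnc(/C(N)=N/NC(=S)N2CCCCCC2)c1`, gives 75.9%

All three share one core: a pyridine-bearing amidrazone joined to a thiocarbonyl carbon that carries a saturated ring. Within the data shown here, compound 2 sits close to both companions; its number lies inside the usual scatter of compound 1 and of compound 3, and the only measured step that touches it, a number 1.6 percentage points lower from compound 1 to compound 2 (within the scatter), is hydrogen in place of methyl on an aromatic carbon, a change that left the read-out essentially unmoved.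

Compound 4, `N/C(=N\NC(=S)N1CCOCC1)c1ccccn1`, is compound 2 with one alteration: morpholin-4-yl in place of thiomorpholin-4-yl on a thiocarbonyl carbon. Among the measured compounds shown here, no measured step changes this ring, so the nearest guide is indirect. Compound 1 and compound 3 differ only in that ring, thiomorpholine against azepane; compound 1 gives 74.2% and compound 3 gives 75.9%, so a ring swap at this position has so far produced no visible shift. Oxygen in place of sulfur in an otherwise identical ring is a smaller change still.

The expectation is therefore a step of a number 2.6 percentage points lower from compound 2 to compound 4 (within the scatter) that stays inside the scatter. Compound 4 is estimated at 70%, with a range from 55% to 84%.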

Compound 4, percent growth inhibition at one concentration: 78.1%
The estimate for compound 4 lay 8.1 percentage points below the measured number; the measured number falls inside the stated range.
By their numbers in this assay, from the lowest: compounds 2, 1, 3 and 4 (each within the scatter of the next).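

Among these compounds, this is the first direct reading of the ring on the thiocarbonyl carbon with everything else in the molecule held fixed. In this assay, among the compounds shown here, morpholin-4-yl in place of thiomorpholin-4-yl gives a number 5.5 percentage points higher from compound 2 to compound 4 (within the scatter) and stays within the usual scatter, so this test cannot tell the oxygen ring from the sulfur ring, even though only one ring atom differs between them. Nothing available here explains why the two rings read alike, and no supporting data bear on the comparison.

As far as these compounds go, what remains open is whether this position responds to anything larger than an exchange of one ring atom, for example a piperazin-1-yl ring with its second nitrogen free, or an open-chain diethylamino group on the same thiocarbonyl carbon. It is also open whether morpholin-4-yl would read the same on a core carrying a methyl on the aromatic carbon, as in compound 1, since the compounds shown pair that methyl only with thiomorpholin-4-yl and azepane rings.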